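Fluoro in Place of Hydrogen: Expected Cytotoxicity of Compound 4

The source may report more compounds than this note shows. Statements on the series, on what has been measured and on what is new or still open speak of the compounds shown alone.

Three compounds have been tested in an ADME assay on HepG2 2.2.15 cells (Homo sapiens) for cytotoxicity, read by MTT assay, with stated times of 48 h and 9 days; a higher number here means that more compound is tolerated, a lower number that less compound is tolerated:

compound 1, `COc1ccc2c(=O)c(/C=C/C(=O)Nc3ccccc3)coc2c1`, gives 523000 nM
compound 2, `COc1ccc2c(=O)c(/C=C/C(=O)NCc3ccccc3)coc2c1`, gives 376000 nM
compound 3, `O=C(/C=C/c1coc2cc(O)ccc2c1=O)Nc1ccccc1`, gives 821000 nM

Among these three numbers compound 1 stands second highest, with compound 2 nearest and compound 3 furthest away. Both steps that start from compound 1 stay within the scatter: a 1.4-fold lower number from compound 1 to compound 2 (0.14 log units; within the scatter) and a 1.6-fold higher number from compound 1 to compound 3 (0.20 log units; within the scatter). The three measured compounds therefore cannot be told apart in this assay.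

Compound 4, `COc1ccc2c(=O)c(/C=C/C(=O)Nc3ccc(F)cc3)coc2c1`, differs from compound 1 by fluoro in place of hydrogen on an aromatic carbon. Neither measured step touches the same spot: one changes the group on the amide-type nitrogen, the other changes the group on an oxygen on the aromatic ring. Still, each of them reshaped a part of compound 1 and stayed within the scatter, and the change leading to compound 4 adds only a single fluorine at the far edge of the molecule.

Because the steps of a 1.4-fold lower number from compound 1 to compound 2 (0.14 log units; within the scatter) and a 1.6-fold higher number from compound 1 to compound 3 (0.20 log units; within the scatter) both stayed within the scatter, compound 4 is expected to show no step beyond the scatter either, a 1.0-fold lower number from compound 1 to compound 4 (0.02 log units; within the scatter). Compound 4 is thus estimated at 500000 nM, within a range from 250000 nM to 1000000 nM.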

Compound 4, half-maximal cytotoxic concentration: 743000 nM
Compound 4: middle estimate off by 1.5-fold (0.17 log units), on the low side, within the range that was stated.
By their numbers in this assay, from the lowest: compounds 2, 1, 4 and 3 (each within the scatter of the next, the first and the last beyond it).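

Compound 4 is the first compound shown with a change on the phenyl ring of the anilide side, at the aromatic carbon para to a large group, and fluoro in place of hydrogen there gives a 1.4-fold higher number from compound 1 to compound 4 (0.15 log units; within the scatter) in this assay for this single change. So this position accepts a fluorine without a step beyond the scatter, which means that compound 1 and compound 4 cannot be told apart here, and the same holds for the larger swap of 4-fluorophenyl in place of benzyl on the amide-type nitrogen, which gives a 2.0-fold higher number from compound 2 to compound 4 (0.30 log units; within the scatter) and shows that even two differences on this side of the molecule leave the result within the scatter. Nothing measured here speaks to what lies behind these small steps.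

A fluorine is only one atom, so the compounds shown leave open whether something quite different at the same carbon, such as an amine or a carboxylic acid, would also stay within the scatter. They also leave open whether a fluorine at another carbon of this ring, or the same fluorine on the core of compound 3, would behave as it does in compound 4.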